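A few compounds are considered here, and "the series" means these few. Any claim that something is new, unique, unknown or untested is made for them only; others in the source may bear on it.

In an ADME assay on Vero cells (Chlorocebus sabaeus) for antiproliferative activity, read by MTT assay, with a stated time of 72 h (a higher number here means a weaker inhibitor, a lower number a stronger inhibitor), compound 1 `COc1cccc(N(C)S(=O)(=O)C2CC3OC2C(c2ccc(NC(=O)CCCCCCC(=O)O)cc2)=C3c2ccc(O)cc2)c1` gives > 100000 nM, which is a limit of the assay and not a number. Compound 2 `CN(c1ccccc1Cl)S(=O)(=O)C1CC2OC1C(c1ccc(NC(=O)CCCCCCC(=O)O)cc1)=C2c1ccc(O)cc1` gives > 100000 nM, which is again only a limit. Compound 2 therefore has no exact place on the scale, and the picture so far is the limit of > 100000 nM in this assay, at which 2 of the 2 values shown sit.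

Compound 3 `CCN(c1ccccc1)S(=O)(=O)C1CC2OC1C(c1ccc(NC(=O)CCCCCCC(=O)O)cc1)=C2c1ccc(O)cc1` keeps the shared core and changes only the group on the sulfonyl sulfur, with ethyl(phenyl)amino in place of (2-chlorophenyl)(methyl)amino (ethyl(phenyl)amino in place of (2-chlorophenyl)(methyl)amino on a sulfonyl sulfur). Among the compounds with values here, the one measured step that bears on this, a step that the two limits leave unreadable from compound 1 to compound 2, put 2-chlorophenyl in place of 3-methoxyphenyl on a sulfonamide nitrogen, so it offers no size to carry over. Given (the limit of > 100000 nM in this assay, at which 2 of the 2 values shown sit), no change beyond the scatter is expected in this assay, and the likeliest report for the new compound is the same limit. The expected step that the limit leaves unreadable from compound 2 to compound 3 is an estimate only. For compound 3 the estimated value is 120000 nM, with an expected range from 60000 nM to 200000 nM.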

Compound 3, half-maximal inhibitory concentration: > 100000 nM
Compound 3: only a limit was reported (the forecaster's own chance of this, stated with the estimate: 85%); the middle value lies beyond the limit too.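

Compound 3, like compound 1 and compound 2, is reported only as a limit in this assay, and the steps joining compound 3 to compound 1 and to compound 2 cannot be read: the limit of > 100000 nM in this assay, at which 3 of the 3 values shown sit.

The compounds shown leave open whether swapping the group on the sulfonyl sulfur changes antiproliferative activity at all.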